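The compounds below may be only part of what the source reports. "The series", "measured", "known", "first", "only" and "open" are said of these compounds alone.

Measured in a functional assay on HUVEC cells (Homo sapiens); a lower number here means that less compound is needed, a higher number that more compound is needed for the effect:
compound 1 `COC1=C(C)C(=O)/C(=C(O)/C=C/c2ccc(O)cc2)C(=O)C1(C)C` gives < 4 ug/mL
compound 2 `COC1=C(C)C(=O)/C(=C(O)/C=C/c2ccc(C)cc2)C(=O)C1(C)C` gives < 4 ug/mL
compound 3 `CCc1ccc(/C=C/C(O)=C2/C(=O)C(C)=C(OC)C(C)(C)C2=O)cc1` gives < 4 ug/mL

Each entry is a limit of the assay and not a number. Compound 3 is known only through its limit of < 4 ug/mL. The other two compounds stand the same way, so no order can be drawn among the three: the limit of < 4 ug/mL in this assay, at which 3 of the 3 values shown sit.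

Next in line is compound 4 `COC1=C(C)C(=O)/C(=C(O)/C=C/c2cc(C)cc(C)c2)C(=O)C1(C)C`, not yet measured in this assay. The change is 3,5-dimethylphenyl in place of 4-ethylphenyl on a double-bonded chain carbon bound to a double-bonded chain carbon, with the same atoms joined differently: 3,5-dimethylphenyl in place of 4-ethylphenyl.

Among the measured compounds shown here, three measured steps bear on it: a step that the two limits leave unreadable from compound 1 to compound 2, a step that the two limits leave unreadable from compound 1 to compound 3 and a step that the two limits leave unreadable from compound 2 to compound 3. None has a readable size, as both ends of each are limits, and none of them reaches 3,5-dimethylphenyl. They offer no size to carry over, so no step beyond the usual scatter is expected in either direction.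

The estimated step is a step that the limit leaves unreadable from compound 3 to compound 4. This expectation rests on compound 3, whose value is the limit < 4 ug/mL. For compound 4 the estimate is 2 ug/mL, with an expected range of 0.6 ug/mL to 6 ug/mL.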

Compound 4, concentration for half-maximal effect: < 4 ug/mL
Compound 4 ended at the assay's limit; the forecaster's own chance of this, stated with the estimate: 70%; the middle value is on the limit's open side.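

In this assay compound 4 gives < 4 ug/mL, a limit and not a number. No step from compound 1, compound 2 or compound 3 to compound 4 can be read, with all four entries at the same limit: the limit of < 4 ug/mL in this assay, at which 4 of the 4 values shown sit.

The compounds shown leave open whether any of the four needs less compound than another for the effect, and by how much.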